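Swapping the bicyclic amine for a sulfoamino-pyrrolidine

The source may hold more compounds than are shown below. What is called first, only, known or untested is meant among the compounds shown, and "the series" means these compounds.

Three amides sharing one core have been measured in a functional assay on HEK293 cells for activation of melanin-concentrating hormone receptor 1 (Rattus norvegicus), read by inositol phosphate accumulation; a lower number here means that less compound is needed, a higher number that more compound is needed for the effect. Compound 1 `CC(C)N(C)c1ccc2cc(NC(=O)CCc3ccc(C(F)(F)F)cc3)ccc2n1` gives 140 nM in this assay, compound 2 `O=C(CCc1ccc(C(F)(F)F)cc1)Nc1ccc2nc(N3CC4CCC3C4)ccc2c1` gives 150 nM, and compound 3 `O=C(CCc1ccc(C(F)(F)F)cc1)Nc1ccc2nc(N3CC4CC3CO4)ccc2c1` gives 70 nM. Compound 3 shows the lowest of the three numbers, but one of the two steps toward it is a 2.0-fold lower number from compound 1 to compound 3 (0.30 log units; within the scatter), and the other is only a 2.1-fold lower number from compound 2 to compound 3 (0.33 log units; beyond the scatter).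

Compound 4 `O=C(CCc1ccc(C(F)(F)F)cc1)Nc1ccc2nc(N3CCC(NS(=O)(=O)O)C3)ccc2c1` differs from compound 3 by a group of 10 heavy atoms (4 carbon, 2 nitrogen, 3 oxygen, 1 sulfur; one five-membered non-aromatic ring with 1 hetero atom) in place of a group of 7 heavy atoms (5 carbon, 1 nitrogen, 1 oxygen; 2 five-membered non-aromatic rings with 1 hetero atom each), on an aromatic carbon. The earlier steps shown here bear on this only loosely: replacing the open-chain amine of compound 1 by a bicyclic amine gave a 1.1-fold higher number from compound 1 to compound 2 (0.03 log units; within the scatter), and the exchange between the two bicyclic amines gave a 2.1-fold lower number from compound 2 to compound 3 (0.33 log units; beyond the scatter). None of them introduced a sulfoamino group or a hydrogen-bond donor at this place, so the new group lies outside what the three measured compounds cover.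

The account therefore expects a step of a 4.3-fold higher number from compound 3 to compound 4 (0.63 log units; beyond the scatter) for compound 4, a modest rise in the number with wide uncertainty, and estimates compound 4 at 300 nM in this assay, between 80 nM and 1500 nM.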

Compound 4, half-maximal effective concentration: 50 nM
Estimate against measurement, compound 4: 6.0-fold (0.78 log units) above; the measured number lies below the stated range.
By their numbers in this assay, from the lowest: compounds 4, 3, 1 and 2 (each within the scatter of the next, the first and the last beyond it).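

In this assay the 3-(sulfoamino)pyrrolidin-1-yl group is tolerated on this aromatic carbon next to the ring nitrogen: exchanging the bicyclic amine gives a 1.4-fold lower number from compound 3 to compound 4 (0.15 log units; within the scatter) and leaves the two compounds indistinguishable. Among these compounds, the same group also gives a 3.0-fold lower number from compound 2 to compound 4 (0.48 log units; beyond the scatter) and a 2.8-fold lower number from compound 1 to compound 4 (0.45 log units; beyond the scatter), both modest steps, so this position accepts a single ring bearing hydrogen-bond donors, which the earlier compounds did not carry there. Nothing on hand explains this result.

The compounds shown leave open what the sulfoamino part adds to the ring alone, which a plain pyrrolidin-1-yl or a 3-aminopyrrolidin-1-yl would separate. Also open, going by these compounds, is whether a carboxylic acid on the same ring would read the same way.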